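Ester for Acid on the Benzyl Arm: Cytotoxicity Outlook

The compounds below may be only part of what the source reports. "The series", "measured", "known", "first", "only" and "open" are said of these compounds alone.

Compound 1 `Cc1cc(/C=C2\SC(=S)N(Cc3ccc(C(=O)O)cc3)C2=O)c(C)n1-c1ccc(O)c(C(=O)O)c1` was examined in an ADME assay on MT2 cells (Homo sapiens) for cytotoxicity, read by XTT assay, with a stated time of 4 days (on this read-out higher numbers stand for lower toxicity in this test and lower numbers for higher toxicity in this test), where compound 1 gives 105000 nM, the higher of the two numbers in hand. Compound 2 `Cc1cc(/C=C2\SC(=S)N(Cc3cccc(Br)c3)C2=O)c(C)n1-c1ccc(O)c(C(=O)O)c1` gives 48200 nM in this assay. Among the measured compounds shown here, the only measured step that touches this part of the molecule is a 2.2-fold lower number from compound 1 to compound 2 (0.34 log units; beyond the scatter). Compound 3 `COC(=O)c1cccc(CN2C(=O)/C(=C/c3cc(C)n(-c4ccc(O)c(C(=O)O)c4)c3C)SC2=S)c1` has not yet been measured; it differs from compound 1 in 3-(methoxycarbonyl)phenyl in place of 4-carboxyphenyl on a saturated chain carbon bound to an amide-type nitrogen in a ring. For the measured compounds named here, that is the same place the measured step alters, and in both cases the 4-carboxyphenyl group leaves, so a modest lowering of the number is expected for compound 3 as well, with the range kept wide because a 2.2-fold lower number from compound 1 to compound 2 (0.34 log units; beyond the scatter) is the sole precedent. Compound 3 is therefore estimated at 60000 nM in this assay, with a range from 30000 nM to 120000 nM. This expectation corresponds to a step of a 1.8-fold lower number from compound 1 to compound 3 (0.24 log units; within the scatter).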

Compound 3, half-maximal cytotoxic concentration: 38500 nM
Compound 3: middle estimate off by 1.6-fold (0.19 log units), on the high side, within the range that was stated.
By their numbers in this assay, from the lowest: compounds 3 and 2 (each within the scatter of the next); then compound 1.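

In this assay there is a 2.7-fold lower number from compound 1 to compound 3 (0.44 log units; beyond the scatter) on the saturated chain carbon bound to an amide-type nitrogen in a ring, so two different groups now give a lower number than 4-carboxyphenyl at this place. The two replacements do not separate, with only a 1.3-fold lower number from compound 2 to compound 3 (0.10 log units; within the scatter) and thus no readable difference between methoxycarbonyl and bromo on an aromatic carbon. No measurement at hand explains this pattern.

The compounds shown leave open whether the higher number of compound 1 belongs to the carboxylic acid itself or to where it sits on the ring, a question that a 3-carboxyphenyl group on the same arm would address. As far as these compounds go, how an unsubstituted phenyl or an aminophenyl group would stand at this place also remains open.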